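The compounds below may be only part of what the source reports. "The series", "measured", "known", "first", "only" and "open" are said of these compounds alone.

Measured compounds in a functional assay on A549 cells (Homo sapiens) for cytotoxicity, read by MTT assay, with a stated time of 72 h; a lower number here means a stronger inhibitor, a higher number a weaker inhibitor:
- compound 1, `Cc1cc(=O)n(-c2ccccc2OC(F)(F)F)nc1C(=O)Nc1ccc(Oc2ncnc3c2ccn3C)cc1`: 25200 nM
- compound 2, `Cc1cc(=O)n(-c2ccc(Br)cc2F)nc1C(=O)Nc1ccc(Oc2ncnc3c2ccn3C)cc1`: 47300 nM

Compound 2 gives the highest of the two numbers in this assay; its nearest neighbour is compound 1, and the step of a 1.9-fold higher number from compound 1 to compound 2 (0.27 log units; within the scatter) lies within the scatter, so the two compounds cannot be ordered on these data.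

Compound 3, `Cc1cc(=O)n(-c2ccc(Br)cc2F)nc1C(=O)Nc1ccc(Oc2ncnc3c2ccn3C)c(F)c1`, differs from compound 2 in one place: fluoro in place of hydrogen on an aromatic carbon. The change sits on the aromatic carbon ortho to a large group and meta to a large group, on the anilide side of the shared core.

Going by the values given here, no measured step touches this position. Among the compounds with values here, the only step recorded, from compound 1 to compound 2, concerns the aryl group on the aromatic nitrogen and is itself within the scatter. There is therefore nothing in the series to point to a shift in either direction for compound 3, and the expected step in this assay is none beyond the scatter.

Compound 3 is expected to give about 45000 nM in this assay, with a range of 15000 nM to 140000 nM, which corresponds to an estimated step of a 1.1-fold lower number from compound 2 to compound 3 (0.02 log units; within the scatter).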

Compound 3, half-maximal inhibitory concentration: 14400 nM
Beside the measured number, compound 3's estimate is 3.1-fold (0.49 log units) above it; measured number below the stated range.
By their numbers in this assay, from the lowest: compounds 3, 1 and 2 (each within the scatter of the next, the first and the last beyond it).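

Fluoro in place of hydrogen on an aromatic carbon, ortho to a large group and meta to a large group, produces the first change in this assay that lies beyond the scatter, a 3.3-fold lower number from compound 2 to compound 3 (0.52 log units; beyond the scatter), although the step is modest. Going by these compounds alone, the only earlier step, a 1.9-fold higher number from compound 1 to compound 2 (0.27 log units; within the scatter), altered the aryl group on the aromatic nitrogen and could not order its two compounds, so this aromatic carbon is so far the only site where a single change separates two compounds. The entering group adds only 1 heavy atom, which shows that a change of this size can be enough to move the number at this site, but nothing available bears on why it does so.

As far as these compounds go, it remains open whether chloro, methyl or methoxy on the same carbon would move the number in the same direction and by a similar amount, or whether fluoro is particular in this respect. From the compounds shown here alone, it also remains open whether the same exchange would give a comparable step with 2-(trifluoromethoxy)phenyl on the aromatic nitrogen in place of 4-bromo-2-fluorophenyl.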